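The source may report more compounds than this note shows. Statements on the series, on what has been measured and on what is new or still open speak of the compounds shown alone.

The study follows four close analogues in an ADME assay on BJ cells (Homo sapiens) for cytotoxicity, read by luminescence, with a stated time of 72 h; on this read-out higher numbers stand for an effect only at larger amounts of compound and lower numbers for an effect already at smaller amounts. Compound 1 `CCOC(=O)c1c(-c2cccc(Cl)c2)[nH]c2cc(OC)c(Cl)cc2c1=O` serves as the reference. In this assay compound 1 gives only a limit, > 21500 nM. Compound 2 `CCOC(=O)c1c(-c2cccc(Br)c2)[nH]c2cc(OC)c(Cl)cc2c1=O` differs from compound 1 by bromo in place of chloro on an aromatic carbon. In this assay compound 2 likewise gives only a limit, > 21500 nM. The resulting step, a step that the two limits leave unreadable from compound 1 to compound 2, therefore has no readable size. Compound 3 `CCOC(=O)c1c(-c2cccc(Cl)c2)[nH]c2cc(OC)c(F)cc2c1=O` has a different core; the two cores differ by fluoro in place of chloro on an aromatic carbon. In this assay compound 3 again gives only a limit, > 21500 nM. The step that the two limits leave unreadable from compound 1 to compound 3 is equally unreadable. What the three measured compounds share is the limit of > 21500 nM in this assay, at which 3 of the 3 values shown sit.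

Compound 4 `CCOC(=O)c1c(-c2cccc(Br)c2)[nH]c2cc(OC)c(F)cc2c1=O` has not yet been measured in this assay. It differs from compound 3 by bromo in place of chloro on an aromatic carbon, and this is the same change that separates compound 1 from compound 2: the place is described in the same words for both pairs, on an aromatic carbon of a six-membered aromatic ring of carbon only, meta to a large group. Compound 4 is expected to give a value around 30000 nM, most probably again as a limit, in a range from 15000 nM to 90000 nM. The expected step is a step that the limit leaves unreadable from compound 3 to compound 4, which rests on the matching change having shown no readable effect because both partners of that pair sit at the limit of > 21500 nM in this assay, at which 3 of the 3 values shown sit.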

Compound 4, half-maximal effective concentration: > 21500 nM
Compound 4: a limit, no number (the forecaster's own chance of this, stated with the estimate: 85%); the middle value does not contradict the limit.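

In this assay compound 4 gives only a limit, > 21500 nM. Neither the step from compound 3 to compound 4 nor the step from compound 2 to compound 4 can be read, and all the compounds share one limit: the limit of > 21500 nM in this assay, at which 4 of the 4 values shown sit.

The compounds shown leave open whether either exchange, bromo for chloro or fluoro for chloro, changes the read-out in this assay at all.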